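Methyl in place of methoxy on the aromatic ring

The source may hold more compounds than are shown below. What is called first, only, known or untested is meant among the compounds shown, and "the series" means these compounds.

Measured in a functional assay on HepG2 cells (Homo sapiens) for inhibition, read by MTT assay, with a stated time of 24 h; a higher number here means a weaker inhibitor, a lower number a stronger inhibitor:
- compound 1 `Cc1ccc(-n2cc(CN3C(=O)C[C@@H]4CC[C@@]3(C)C4(C)C)nn2)cc1`: 480 nM
- compound 2 `CC1(C)[C@H]2CC[C@]1(C)N(Cc1cn(-c3cccc(Br)c3)nn1)C(=O)C2`: 20 nM
- compound 3 `COc1cccc(-n2cc(CN3C(=O)C[C@@H]4CC[C@@]3(C)C4(C)C)nn2)c1`: 70 nM

All three compounds share one core and differ only in the aromatic group attached to it. Compound 3 holds the second highest of the three numbers, with compound 2 lower and compound 1 higher. The next compound, compound 4 `Cc1cccc(-n2cc(CN3C(=O)C[C@@H]4CC[C@@]3(C)C4(C)C)nn2)c1`, keeps that core and makes one small change: methyl in place of methoxy on an aromatic carbon. In other words, 3-methylphenyl replaces 3-methoxyphenyl.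

Going by the values given here, no measured step makes this exact swap, so the nearest ones have to serve. Methoxy in place of bromo gave a 3.5-fold higher number from compound 2 to compound 3 (0.54 log units; beyond the scatter), a modest step which shows that the group at this place can move the number. Larger differences appear when the group itself is exchanged: 3-methoxyphenyl in place of 4-methylphenyl gave a 6.9-fold lower number from compound 1 to compound 3 (0.84 log units; beyond the scatter), and 3-bromophenyl in its place gave a 24-fold lower number from compound 1 to compound 2 (1.38 log units; beyond the scatter). Compound 4 has the methyl group of compound 1, but on the ring position of compound 3, so it is expected to sit nearer compound 3 and compound 2 than compound 1. No step beyond the scatter is therefore expected in this assay, only an estimated 1.2-fold lower number from compound 3 to compound 4 (0.07 log units; within the scatter). For compound 4 the estimate is 60 nM, with an expected range from 20 nM to 200 nM.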

Compound 4, half-maximal inhibitory concentration: 300 nM
The estimate for compound 4 lay 5.0-fold (0.70 log units) below the measured number; measured number outside the range, above it.
By their numbers in this assay, from the lowest: compound 2; then compound 3; then compounds 4 and 1 (each within the scatter of the next).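

In this assay, holding the ring position fixed and changing only the group shows that the group itself matters: methyl in place of methoxy gave a 4.3-fold higher number from compound 3 to compound 4 (0.63 log units; beyond the scatter) and methyl in place of bromo gave a 15-fold higher number from compound 2 to compound 4 (1.18 log units; beyond the scatter) on the same ring carbon. The shift from 4-methylphenyl to 3-methylphenyl gave a 1.6-fold lower number from compound 1 to compound 4 (0.20 log units; within the scatter) and so cannot be told apart from no change, which means this ring position alone does not bring a low number; among these four compounds, low numbers appear only with bromo or methoxy there. Nothing available here explains why methyl differs so clearly from the other two groups on this ring carbon.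

On these data alone, whether an amine, a carboxylic acid or a longer chain such as ethoxy on this ring carbon would give a number closer to that of compound 2 or to that of compound 4 remains open. Also open, as far as these compounds go, is whether bromo or methoxy would keep their low numbers at the ring position that carries the methyl group in compound 1.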